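The source may hold more compounds than are shown below. What is called first, only, known or untested is meant among the compounds shown, and "the series" means these compounds.

Compound 1, `CCN(CC)c1ccc2cc(C(=O)c3ccc(N4CCN(C(=O)CN5CCN(C(=O)/C=C/c6ccccc6)CC5)CC4)cc3)oc2c1`, in an ADME assay on L02 cells (Homo sapiens) for cytotoxicity, read by MTT assay, with a stated time of 48 h (a higher number here means a weaker inhibitor, a lower number a stronger inhibitor), gives > 100000 nM, which is a limit of the assay and not a number.
Compound 2, `CCN(CC)c1ccc2cc(C(=O)c3ccc(N4CCN(C(=O)CN5CCN(S(=O)(=O)C6CC6)CC5)CC4)cc3)oc2c1`, in this assay gives > 100000 nM, again a limit of the assay rather than a number.

The two measured compounds share one core and differ only in the group on an amine nitrogen in a ring. The step between them, a step that the two limits leave unreadable from compound 1 to compound 2, cannot be sized, since both ends sit at the limit of > 100000 nM in this assay, at which 2 of the 2 values shown sit. Compound 2 therefore stands at the limit of this assay, with no measured number to place it against.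

Compound 3, `CCN(CC)c1ccc2cc(C(=O)c3ccc(N4CCN(C(=O)CN5CCN(S(=O)(=O)c6ccc(C#N)cc6)CC5)CC4)cc3)oc2c1`, differs from compound 2 only in 4-cyanophenyl in place of cyclopropyl on a sulfonyl sulfur. Going by the values given here, no measured step bears directly on this exchange: the one step known changed a different group and was itself unreadable. With both measured compounds at the limit, the expectation for compound 3 is that it too reports a limit, so the estimated step of a number no higher from compound 2 to compound 3 (the limit leaves the size open) amounts to no step beyond the scatter. Compound 3 is estimated to give 100000 nM in this assay, within 50000 nM to 200000 nM.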

Compound 3, half-maximal inhibitory concentration: 44100 nM
The estimate for compound 3 lay 2.3-fold (0.36 log units) above the measured number, outside the stated range (below it).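

Going by these compounds alone, exchanging cyclopropyl for 4-cyanophenyl on a sulfonyl sulfur gives an at least 2.2-fold lower number from compound 2 to compound 3 (0.35 log units; beyond the scatter), the first readable step, and it shows that the group at this place can bring the number in this assay off the limit. Set against the (2-phenylethenyl)carbonyl group on the same amine nitrogen in a ring, (4-cyanophenyl)sulfonyl gives an at least 2.2-fold lower number from compound 1 to compound 3 (0.35 log units; beyond the scatter), so the change is tied to the whole group and not to the sulfonyl alone, since compound 2 also carries a sulfonyl and reports only a limit. The step from compound 1 to compound 2 cannot be read, and both readable steps give only a minimum size, as their starting compounds report a limit of the assay and not a number: the limit of > 100000 nM in this assay, at which 2 of the 3 values shown sit.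

The compounds shown leave open whether the nitrile or the six-membered aromatic ring accounts for the step, which a plain phenyl on the same sulfur would separate. They also leave open how the number would respond to a carboxylic acid or an amine at the place the nitrile holds in compound 3.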